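The compounds below may be only part of what the source reports. "The series", "measured", "known", "first", "only" and "open" are said of these compounds alone.

Measured so far in an assay on C3H 10T1/2 cells for inhibition of Sonic hedgehog protein (Mus musculus), read by a luciferase reporter; a higher number here means a weaker inhibitor, a lower number a stronger inhibitor:
compound 1 `Cc1nc(C(F)(F)F)ccc1C(=O)Nc1ccc(Cl)c(-c2nc3ccccc3[nH]2)c1` gives 12 nM
compound 2 `Cc1nc(C(F)(F)F)ccc1C(=O)Nc1ccc(Cl)c(-c2nc3c(n2C)CCCC3)c1` gives 150 nM
compound 3 `Cc1nc(C(F)(F)F)ccc1C(=O)Nc1ccc(Cl)c(C(=O)Nc2ccccc2)c1` gives 140 nM

Compound 3 stands second highest of the three numbers. Against compound 2 the difference is a 1.1-fold lower number from compound 2 to compound 3 (0.03 log units; within the scatter), so the two are not told apart. Against compound 1 the gap is a 12-fold higher number from compound 1 to compound 3 (1.07 log units; beyond the scatter), a large step.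

Compound 4 `Cc1nc(C(F)(F)F)ccc1C(=O)Nc1ccc(Cl)c(-c2cnccn2)c1` arises from compound 3 by pyrazin-2-yl in place of phenylcarbamoyl on an aromatic carbon. Among the compounds with values here, two steps bear on it. Within the data shown here, the only large steps, a 12-fold higher number from compound 1 to compound 3 (1.07 log units; beyond the scatter) and a 13-fold higher number from compound 1 to compound 2 (1.10 log units; beyond the scatter), both run from the benzimidazol-2-yl of compound 1, which carries a hydrogen-bond donor, to groups without it, and the two donor-free groups in compound 2 and compound 3 sit together, a 1.1-fold lower number from compound 2 to compound 3 (0.03 log units; within the scatter). Pyrazin-2-yl likewise brings no donor, so in this assay compound 4 is expected to stay near compound 3, with a step of about a 1.4-fold lower number from compound 3 to compound 4 (0.15 log units; within the scatter), not clearly beyond the scatter in either direction. The estimate for compound 4 is therefore 100 nM, within 30 nM to 400 nM.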

Compound 4, half-maximal inhibitory concentration: 1700 nM
Beside the measured number, compound 4's estimate is 17-fold (1.23 log units) below it; the whole stated range lies below it.
By their numbers in this assay, from the lowest: compound 1; then compounds 3 and 2 (each within the scatter of the next); then compound 4.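

In this assay, pyrazin-2-yl on this aromatic carbon, ortho to a chloro group, gives a higher number than all three earlier groups, with a 12-fold higher number from compound 3 to compound 4 (1.08 log units; beyond the scatter) and an 11-fold higher number from compound 2 to compound 4 (1.05 log units; beyond the scatter) and a 140-fold higher number from compound 1 to compound 4 (2.15 log units; beyond the scatter) as the steps. The three groups of 9 or 10 heavy atoms all give lower numbers than the smaller pyrazin-2-yl, yet the equal count in compound 1 and compound 3 shows that heavy-atom count alone does not set the number. No measurement on hand accounts for the change.

Still open, as far as these compounds go, is whether the ring nitrogens or the smaller group goes with the higher number. Pyridin-2-yl or an unsubstituted phenyl on the same carbon would help to separate the two.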